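Methylcyclopropyl amide on the bicyclic core: expected response

The source may report more compounds than this note shows. Statements on the series, on what has been measured and on what is new or still open speak of the compounds shown alone.

Compounds measured in an assay on SH-EP1 cells for agonist activity at Neuronal acetylcholine receptor; alpha4/beta2 (Homo sapiens), read by FLIPR and calcium flux; a lower number here means a smaller maximal response, a higher number a larger maximal response:
compound 1 `CCC(=O)N1CC2CC(C1)N2` gives 98%
compound 2 `O=C([C@@H]1C[C@@H]1F)N1CC2CC(C1)N2` gives 120%

Compound 2 stands highest of the two numbers in this assay; its nearest neighbour is compound 1, and the step of a number 22 percentage points higher from compound 1 to compound 2 (beyond the scatter) lies beyond the scatter. Within the data shown here, that step, 2-fluorocyclopropyl in place of ethyl on a carbonyl carbon, is the only measured step and it exchanges a chain for a ring.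

Compound 3 `C[C@@H]1C[C@H]1C(=O)N1CC2CC(C1)N2` is not yet measured. It differs from compound 2 as follows: 2-methylcyclopropyl in place of 2-fluorocyclopropyl on a carbonyl carbon. Here the ring is kept and only one of its substituents is exchanged, so the measured step bears on it only indirectly: it shows that the ring itself was tolerated and gave a larger maximal response than the chain, but it says nothing about fluorine against methyl on that ring. Among the measured compounds shown here, with no step of this kind measured, the account expects compound 3 to remain near compound 2, with a number 10 percentage points lower from compound 2 to compound 3 (within the scatter) not clearly beyond the scatter in either direction. The estimate for compound 3 in this assay is 110%, with a range from 90% to 130%.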

Compound 3, largest response reached (Emax), in percent of the reference or control that the assay uses: 110%
Beside the measured number, compound 3's estimate shows no gap at the digits printed; the measured number falls inside the stated range.
By their numbers in this assay, from the lowest: compound 1; then compounds 3 and 2 (each within the scatter of the next).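

In this assay, among these compounds, the exchange on the carbonyl carbon gives a number 10 percentage points lower from compound 2 to compound 3 (within the scatter), so at this position the 2-fluorocyclopropyl and 2-methylcyclopropyl groups cannot be told apart, something the earlier compounds could not show with only one ring-bearing amide among them. The ring without fluorine also stands clear of the ethyl group, with a number 12 percentage points higher from compound 1 to compound 3 (beyond the scatter), which shows that the larger maximal response over compound 1 is not confined to the fluorine-bearing ring: both ring-bearing compounds share it, and neither goes against it. Nothing available gives a reason for either step.

What the compounds shown leave open is how the bare cyclopropyl group, with neither fluorine nor methyl on the ring, or a larger cyclobutyl group would stand on the same carbonyl carbon, and so whether the ring alone carries the difference from the ethyl group. Also open, going by these compounds, is how the opposite arrangement at the two defined stereocentres of the 2-methylcyclopropyl group would read in this assay.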